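Swapping the aryl group on the sulfonyl sulfur once more

The source may report more compounds than this note shows. Statements on the series, on what has been measured and on what is new or still open speak of the compounds shown alone.

Compound 1 `CC1CCN(c2c(S(=O)(=O)c3ccc(Cl)cc3)cnc3ccc(F)cc23)CC1`: in an assay on isolated protein for displacement of a labelled ligand from metabotropic glutamate receptor 5 (Homo sapiens), with a stated time of 60 min, tested at 1 uM (a lower number here means less inhibition, a higher number more inhibition at the concentration tested (going by the name of the read-out)), compound 1 gives 80%.
Compound 2 `Cc1ccc(S(=O)(=O)c2cnc3ccc(F)cc3c2N2CCC(C)CC2)cc1F`: in this assay compound 2 gives 86%.
Compound 3 `COc1cccc(S(=O)(=O)c2cnc3ccc(F)cc3c2N2CCC(C)CC2)c1`: in this assay compound 3 gives 90%.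

Compound 3 holds the highest of the three numbers shown, yet none of the three is separated from another by more than the scatter: the step of a number 10 percentage points higher from compound 1 to compound 3 (within the scatter) is within the scatter, as is a number 6 percentage points higher from compound 1 to compound 2 (within the scatter) and the step of a number 4 percentage points higher from compound 2 to compound 3 (within the scatter). All three compounds share the same core and differ only in the aryl group carried on the sulfonyl sulfur.

Compound 4 `CC1CCN(c2c(S(=O)(=O)c3cc(Cl)cc(Cl)c3)cnc3ccc(F)cc23)CC1` differs from compound 3 in the same place: 3,5-dichlorophenyl in place of 3-methoxyphenyl on a sulfonyl sulfur. Every measured step bearing on this position is an exchange of one aryl group for another on that sulfur, and each of them stayed within the scatter. The expectation for compound 4 is therefore no step beyond the scatter in this assay, in either direction. Compound 4 is thus estimated at 85%, with a range from 70% to 95%. The step of a number 5 percentage points lower from compound 3 to compound 4 (within the scatter) is expected to stay within the scatter.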

Compound 4, a percentage reported as inhibition, at one concentration (the size of the read-out at that concentration, not a potency): 69%
The estimate for compound 4 lay 16 percentage points above the measured number, and the stated range ends above it.
By their numbers in this assay, from the lowest: compound 4; then compounds 1, 2 and 3 (each within the scatter of the next).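

Aryl exchanges on the sulfonyl sulfur are not all interchangeable in this assay: 3,5-dichlorophenyl in place of 3-methoxyphenyl gives a number 21 percentage points lower from compound 3 to compound 4 (beyond the scatter) while no step among compound 1, compound 2 and compound 3 left the scatter. Compound 4 also stands apart from the other two, with a number 17 percentage points lower from compound 2 to compound 4 (beyond the scatter) and a number 11 percentage points lower from compound 1 to compound 4 (beyond the scatter) and yet compound 1 carries chlorine on its aryl group too and stays within the scatter of compound 2 and compound 3, so chlorine alone does not mark the lower number. Nothing available explains this step at the sulfonyl sulfur.

The compounds shown leave open whether a 3-chlorophenyl or a 3,5-dimethoxyphenyl group on this sulfur would read like compound 3 or like compound 4. Also open, from the compounds shown here alone, is what an aryl group bearing an amine or a carboxylic acid would give here.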